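A new amide aryl group on compound 2

The source may report more compounds than this note shows. Statements on the series, on what has been measured and on what is new or still open speak of the compounds shown alone.

In a functional assay on HT-29 cells (Homo sapiens) for cytotoxicity, read by MTT assay, with a stated time of 72 h (a higher number here means a weaker inhibitor, a lower number a stronger inhibitor), compound 1 `O=C(CN1CCN(c2nnc(Cc3ccncc3)c3ccccc23)CC1)Nc1ccc(Br)cc1` gives 1990 nM and compound 3 `O=C(CN1CCN(c2nnc(Cc3ccncc3)c3ccccc23)CC1)Nc1ccc(F)c(F)c1` gives 2320 nM. Compound 2 `O=C(CN1CCN(c2nnc(Cc3ccccc3)c3ccccc23)CC1)Nc1ccc(Br)cc1` has the highest number of the three, at 60200 nM. Phenyl in place of pyridin-4-yl on a saturated chain carbon bound to an aromatic carbon marks a large step, a 30-fold higher number from compound 1 to compound 2 (1.48 log units; beyond the scatter).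

Compound 4 `O=C(CN1CCN(c2nnc(Cc3ccccc3)c3ccccc23)CC1)Nc1ccc(F)c(Cl)c1` keeps that phenyl but carries 3-chloro-4-fluorophenyl in place of 4-bromophenyl on an amide-type nitrogen. The large step therefore concerns a part that stays unchanged here. The measured step closest to the new change is 3,4-difluorophenyl in place of 4-bromophenyl on an amide-type nitrogen, a 1.2-fold higher number from compound 1 to compound 3 (0.07 log units; within the scatter), which stays within the scatter. That single pair carries pyridin-4-yl, however, and no exchange at the amide has been measured with phenyl in that place, so the expectation remains uncertain.

Resting on that small step, no change beyond the scatter is expected, and the expected step is a 1.2-fold lower number from compound 2 to compound 4 (0.08 log units; within the scatter). For compound 4 the estimated value is 50000 nM, with an expected range from 15000 nM to 120000 nM.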

Compound 4, half-maximal inhibitory concentration: 13300 nM
The estimate for compound 4 lay 3.8-fold (0.58 log units) above the measured number; the whole stated range lies above it.
By their numbers in this assay, from the lowest: compounds 1 and 3 (each within the scatter of the next); then compound 4; then compound 2.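

The amide aryl group proves able to move the number in this assay when phenyl stands in place of pyridin-4-yl: 3-chloro-4-fluorophenyl in place of 4-bromophenyl on the amide-type nitrogen gives a 4.5-fold lower number from compound 2 to compound 4 (0.66 log units; beyond the scatter). This is the first exchange at that place shown to go beyond the scatter, whereas the one earlier exchange there, made with pyridin-4-yl and with a different entering group, gave a 1.2-fold higher number from compound 1 to compound 3 (0.07 log units; within the scatter). The place on the amide-type nitrogen therefore cannot be treated as silent across the series, although the step is smaller than the one seen on replacing pyridin-4-yl with phenyl. Nothing shown here explains the drop in the number on this exchange.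

The two amide exchanges differ both in the entering group and in the group on the saturated chain carbon, so the compounds shown leave open which of these accounts for the difference in step size. They also leave open how the number would respond on the phenyl compounds to an unsubstituted phenyl, or to a phenyl carrying a carboxylic acid, on the amide-type nitrogen.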